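A few compounds are considered here, and "the series" means these few. Any claim that something is new, unique, unknown or untested is made for them only; others in the source may bear on it.

Of the compounds shown here, three sharing one core have been tested in a functional assay on PC-6 cells (Homo sapiens) for cytotoxicity, read by MTT assay, with a stated time of 3 days; on this read-out lower numbers stand for stronger inhibition and higher numbers for weaker inhibition. Compound 1 (`CC(C)(C)c1cc2c(N/N=C/c3ccc4c(c3)CNCC4)ncnc2s1`) gives 0.069 ug/mL, compound 2 (`CC(C)(C)c1cc2c(N/N=C/c3ccc(C(=O)O)cc3)ncnc2s1`) gives 7.22 ug/mL, and compound 3 (`CC(C)(C)c1cc2c(N/N=C/c3ccc(CN)cc3)ncnc2s1`) gives 0.214 ug/mL. Compound 3 thus holds the middle place: its number is higher than that of compound 1 and much lower than that of compound 2, with both gaps beyond the scatter.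

Compound 4 (`CNCc1ccc(/C=N/Nc2ncnc3sc(C(C)(C)C)cc23)cc1`) departs from compound 3 at a single point: methyl in place of hydrogen on an amine nitrogen. Among the measured compounds shown here, no measured step makes this exact change. The nearest is a 34-fold lower number from compound 2 to compound 3 (1.53 log units; beyond the scatter), a large step in which aminomethyl replaces carboxy. Compound 4 keeps an amine, however, so a step of that size is not expected. Compound 1, which also carries an amine, gives 0.069 ug/mL, which leaves a slightly lower number as the more likely direction. The expected step is small: a 1.3-fold lower number from compound 3 to compound 4 (0.13 log units; within the scatter). For compound 4 the estimated value is 0.16 ug/mL, with an expected range from 0.06 ug/mL to 0.45 ug/mL.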

Compound 4, half-maximal inhibitory concentration: 0.044 ug/mL
Compound 4: the middle estimate sits 3.6-fold (0.56 log units) above what was measured; measured number outside the range, below it.
By their numbers in this assay, from the lowest: compounds 4 and 1 (each within the scatter of the next); then compound 3; then compound 2.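

In this assay, the amine nitrogen of the aminomethyl group responds to one added carbon: going from aminomethyl to (methylamino)methyl gives a 4.9-fold lower number from compound 3 to compound 4 (0.69 log units; beyond the scatter), so a methyl in place of hydrogen at this nitrogen is tolerated and lowers the number. The earlier step compared carboxy with aminomethyl only; replacing carboxy with (methylamino)methyl gives a 160-fold lower number from compound 2 to compound 4 (2.22 log units; beyond the scatter), which shows that the low number does not depend on an unsubstituted amino group at this place. No measurement given here accounts for the effect of the added methyl.

On these data alone, whether a dimethylamino group or an ethyl group on the same nitrogen would lower the number again remains open. So does whether an acetyl group there, which would turn the amine into an amide, would keep the number low.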